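Naphthalen-2-yl for 4-chlorophenyl: estimate for compound 3

This account rests on a few compounds, and the source may have more. Where it says the series, first, only, none or still open, it means among the compounds named here.

Compound 1 `CCCSc1nc(N/N=C/c2ccc(Cl)cc2)c2nnn(Cc3ccccc3)c2n1` stands at the edge of a functional assay on ECa-109 cells (Homo sapiens) for antiproliferative activity, read by MTT assay, with a stated time of 72 h; a higher number here means a weaker inhibitor, a lower number a stronger inhibitor: compound 1 gives > 64000 nM, which is a limit of the assay and not a number (the limit of > 64000 nM in this assay, at which 1 of the 2 values shown sits). Compound 2 `CCCSc1nc(N/N=C(\C)c2ccccc2O)c2nnn(Cc3ccccc3)c2n1` gives 11100 nM in this assay. Among the compounds with values here, the only measured step, an at least 5.7-fold lower number from compound 1 to compound 2 (0.76 log units; beyond the scatter), exchanges the group on the nitrogen on an aromatic ring and is the sole step that bears on the present change. Compound 3 `CCCSc1nc(N/N=C/c2ccc3ccccc3c2)c2nnn(Cc3ccccc3)c2n1` differs from compound 1 by naphthalen-2-yl in place of 4-chlorophenyl on a carbon with a double bond to nitrogen. Because compound 1 rests at a limit (the limit of > 64000 nM in this assay, at which 1 of the 2 values shown sits), the step to compound 3 has no fixed starting number. The pair of groups exchanged between compound 1 and compound 2 is not the pair exchanged here, so neither its direction nor its size transfers. For compound 3 the expected value is 45000 nM, within a range of 9000 nM to 200000 nM. The expected step is an at least 1.4-fold lower number from compound 1 to compound 3 (0.15 log units; that floor lies within the scatter), with wide uncertainty.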

Compound 3, half-maximal inhibitory concentration: > 64000 nM
Compound 3 ended at the assay's limit (the forecaster's own chance of this, stated with the estimate: 55%); at least 1.4-fold (0.15 log units) between middle value and limit.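

In this assay compound 3 gives > 64000 nM as a limit and not a number. Compound 1 also rests at a limit, so no step from compound 1 to compound 3 can be read: the limit of > 64000 nM in this assay, at which 2 of the 3 values shown sit.

Left open is whether naphthalen-2-yl and 4-chlorophenyl differ at all in this series.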